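Furan attachment swap: compound 3 to compound 4

The compounds below may be only part of what the source reports. "The series", "measured", "known", "first", "only" and "open" are said of these compounds alone.

Compound 3 `CCC(CC)OC(=O)C1=C(C)NC(=O)NC1c1ccco1` shares its core with compound 1 `CC(=O)C1=C(C)NC(=O)NC1c1ccoc1` and compound 2 `CC1=C(C(=O)NC(C)C)C(c2ccoc2)NC(=O)N1`. In an assay on membranes from CHO cells for displacement of a labelled ligand from adenosine receptor A1 (Homo sapiens), read by scintillation counting, with a stated time of 60 min, tested at 1 uM (on this read-out higher numbers stand for more inhibition at the one concentration tested (going by the name of the read-out) and lower numbers for less inhibition), compound 1 gives 6%, compound 2 gives 1% and compound 3 gives 2%. Compound 3 stands second highest of the three numbers, and its gaps to compound 2 and to compound 1 both lie within the scatter. Within the data shown here, the only measured single step, a number 5 percentage points lower from compound 1 to compound 2 (within the scatter), concerns the group on a carbonyl carbon, not the furan. Compound 4 `CCC(CC)OC(=O)C1=C(C)NC(=O)NC1c1ccoc1` differs from compound 3 by furan-3-yl in place of furan-2-yl on a saturated ring carbon. Among the measured compounds shown here, no measured step bears on this change, so no step beyond the scatter is expected in this assay. Compound 4 is expected to show a number 1 percentage points higher from compound 3 to compound 4 (within the scatter). Compound 4 is estimated at 3%, between -5% and 12%.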

Compound 4, a percentage reported as inhibition, at one concentration (the size of the read-out at that concentration, not a potency): 17%
Beside the measured number, compound 4's estimate is 14 percentage points below it; measured number outside the range, above it.
By their numbers in this assay, from the lowest: compounds 2, 3 and 1 (each within the scatter of the next); then compound 4.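

In this assay the attachment point of the furan on the saturated ring carbon matters: with (pentan-3-yl)oxy kept on the carbonyl carbon, the swap to furan-3-yl gives a number 15 percentage points higher from compound 3 to compound 4 (beyond the scatter) as the step. With furan-3-yl kept, (pentan-3-yl)oxy gives a number 16 percentage points higher from compound 2 to compound 4 (beyond the scatter) against isopropylamino and a number 11 percentage points higher from compound 1 to compound 4 (beyond the scatter) against methyl, so the group on the carbonyl carbon also counts here. No evidence at hand accounts for either change.

Open, as far as these compounds go, is whether the furan swap gives a similar step with methyl or isopropylamino on the carbonyl carbon. Also open, from the compounds shown here alone, is how a thiophene in place of the furan, or a longer chain on the carbonyl oxygen, would read.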